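Fluoro to chloro on the sulfonyl aryl ring

The source may report more compounds than this note shows. Statements on the series, on what has been measured and on what is new or still open speak of the compounds shown alone.

Measured so far in an assay on HEK293 cells for negative allosteric modulation of metabotropic glutamate receptor 5 (Homo sapiens), read by FLIPR; a higher number here means a weaker inhibitor, a lower number a stronger inhibitor:
compound 1 `O=S(=O)(c1ccc(F)cc1)N1CC(c2nc(-c3cccc(Cl)c3)no2)C1`: 130 nM
compound 2 `O=C(C1CCC(C(F)(F)F)CC1)N1CC(c2nc(-c3cccc(F)c3)no2)C1`: > 10000 nM
compound 3 `O=C(C1CCC(C(F)(F)F)CC1)N1CC(c2nc(-c3cccc(Cl)c3)no2)C1`: > 10000 nM

Among the compounds with values here, compound 1 gives 130 nM in this assay, the only number in this set. Compound 2 gives > 10000 nM, which is a limit of the assay and not a number. Compound 3 gives > 10000 nM, again a limit. The difference between the core of compound 1 and the core of compound 2 is not broken down here.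

Between compound 2 and compound 3 the change is chloro in place of fluoro on an aromatic carbon. The step that the two limits leave unreadable from compound 2 to compound 3 cannot be read because of the limit of > 10000 nM in this assay, at which 2 of the 3 values shown sit.

Compound 4 `O=S(=O)(c1ccc(Cl)cc1)N1CC(c2nc(-c3cccc(Cl)c3)no2)C1` is not yet measured. It differs from compound 1 by chloro in place of fluoro on an aromatic carbon. This is the same kind of change as that from compound 2 to compound 3, but not the same: in compound 3 the chloro sits meta to a large group, in compound 4 it sits para to a large group.

The measured pair gives no size for this change, so the expectation rests on compound 1 alone, which gives 130 nM. The step of a 1.3-fold lower number from compound 1 to compound 4 (0.11 log units; within the scatter) is expected to lie within the usual scatter. Compound 4 is therefore estimated at 100 nM, with a likely range from 35 nM to 300 nM.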

Compound 4, half-maximal inhibitory concentration: 170 nM
Beside the measured number, compound 4's estimate is 1.7-fold (0.23 log units) below it, and the stated range covers the measured number.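

In this assay, 4-fluorophenyl to 4-chlorophenyl on the core of compound 1, para to a large group, gives a 1.3-fold higher number from compound 1 to compound 4 (0.12 log units; within the scatter), so the two values cannot be told apart and on this core the swap is tolerated. The same kind of change on the other core, from compound 2 to compound 3, gives no size to set against this step, and it sits at a different place on the molecule, so neither the size nor the direction can be compared between the two cores: the limit of > 10000 nM in this assay, at which 2 of the 4 values shown sit. This leaves one readable step on one core, which shows that chloro can stand in place of fluoro at this position of the core of compound 1, but does not show that the change would read the same on any other core in the series.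

The compounds shown leave open how far this position accepts groups other than the two halogens, such as a methyl, a methoxy, a nitrile or a trifluoromethyl in the same place. They also leave open whether a fluoro or a plain hydrogen in place of the chloro on the other aromatic ring would hold the value on this core.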